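Solubility of a quinoline ether amide series

The compounds below may be only part of what the source reports. "The series", "measured", "known", "first", "only" and "open" are said of these compounds alone.

Measured compounds:
compound 1 `Cc1cc(C)cc(NC(=O)COc2cc(C)nc3ccc(Cl)cc23)c1` — 8000 nM
compound 2 `COc1ccc2nc(C)cc(OCc3ccc4ccccc4n3)c2c1` — 21000 nM
compound 3 `COc1ccc2nc(C)cc(OCC(=O)Nc3cccc(C)c3)c2c1` — 193000 nM

Of the compounds shown here, three sharing a quinoline ether core have been measured in a physicochemical assay for solubility, in phosphate buffer, measured as kinetic solubility, with a stated time of 1 h, at pH 7.4; on this read-out lower numbers stand for lower solubility and higher numbers for higher solubility. Compound 3 `COc1ccc2nc(C)cc(OCC(=O)Nc3cccc(C)c3)c2c1` stands highest of the three, at 193000 nM. Its nearest neighbour is compound 2, which gives 21000 nM, a gap beyond the scatter; compound 1, with 8000 nM, lies furthest away, also beyond the scatter.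

The piece now follows the step from compound 3 to compound 4 `COc1ccc2nc(C)cc(OCC(=O)Nc3ccc(Cl)cc3)c2c1`, which is not yet measured. The change is 4-chlorophenyl in place of 3-methylphenyl on an amide-type nitrogen. The amide linkage and the core are kept; only the aryl group on the amide nitrogen is exchanged, from 3-methylphenyl to 4-chlorophenyl.

Within the data shown here, no step between measured compounds isolates such an exchange, so the expectation rests on the spread of the three values alone. A modest decrease in this assay is expected for compound 4, roughly a 2.4-fold lower number from compound 3 to compound 4 (0.38 log units; beyond the scatter), though a result within the scatter of compound 3 would not surprise. Compound 4 is therefore estimated at 80000 nM, with a range from 25000 nM to 250000 nM.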

Compound 4, solubility: 9000 nM
Compound 4: middle estimate off by 8.9-fold (0.95 log units), on the high side, outside the stated range (below it).
By their numbers in this assay, from the lowest: compounds 1 and 4 (each within the scatter of the next); then compound 2; then compound 3.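

In this assay, putting 4-chlorophenyl in place of 3-methylphenyl on the amide-type nitrogen gives a 21-fold lower number from compound 3 to compound 4 (1.33 log units; beyond the scatter). Among these compounds, this is the first step that isolates a single change, and it shows that the read-out can move by a large step, beyond the scatter, through the aryl group on this nitrogen alone, with the amide linkage and the core kept. The two groups match in heavy-atom count and in counted hydrogen-bond donors and acceptors, and nothing at hand accounts for the size of the step.

The compounds shown do not separate the exchange of methyl for chlorine from the different placement in the two names, which 3-chlorophenyl or 4-methylphenyl could address. Also open, going by these compounds, is what an amine or a carboxylic acid on this aryl ring would give.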